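Pyridazinyl versus pyridinyl side groups and plasma protein binding

This account rests on a few compounds, and the source may have more. Where it says the series, first, only, none or still open, it means among the compounds named here.

In an ADME assay on a cell-free system (plasma, Homo sapiens) for protein binding, compound 1 `Cc1ccc([C@@H](C)Oc2cc3onc(CCC(=O)O)c3cc2Cl)nc1` gives 99.7%, and compound 2 `C[C@@H](Oc1cc2onc(CCC(=O)O)c2cc1Cl)c1ccc(Cl)cn1` gives 99.8%; these two lie within the scatter of each other, a 1.5-fold lower unbound fraction from compound 1 to compound 2 (0.18 log units; within the scatter). Compound 3 `Cc1ccc([C@@H](C)Oc2cc3onc(CCC(=O)O)c3cc2Cl)nn1` gives 92.9% and holds the highest unbound fraction of the three, a 24-fold higher unbound fraction from compound 1 to compound 3 (1.37 log units; beyond the scatter) and a 36-fold higher unbound fraction from compound 2 to compound 3 (1.55 log units; beyond the scatter).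

Compound 4 `C[C@@H](Oc1cc2onc(CCC(=O)O)c2cc1Cl)c1ccccn1` differs from compound 3 by pyridin-2-yl in place of 6-methylpyridazin-3-yl on a saturated chain carbon bound to an oxygen on an aromatic ring and a saturated chain carbon. The two large steps into compound 3 both went from a pyridinyl to the pyridazinyl group, so returning to a pyridinyl group is expected to undo most of that gain in unbound fraction and to sit nearer compounds 1 and 2; whether the absent methyl matters is not covered by these data. Compound 4 is therefore estimated at 99.3% in this assay, within 97.5% to 99.8%, an expected step of a 10-fold lower unbound fraction from compound 3 to compound 4 (1.01 log units; beyond the scatter).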

Compound 4, plasma protein binding in the plasma assay: 97.8%
Beside the measured number, compound 4's estimate is 3.1-fold (0.50 log units) (unbound fraction) below it; the measured number falls inside the stated range.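

In the plasma assay, pyridin-2-yl recovers only part of the binding lost with 6-methylpyridazin-3-yl, a 3.2-fold lower unbound fraction from compound 3 to compound 4 (0.51 log units; beyond the scatter), while hydrogen in place of methyl or chloro on an aromatic carbon also moves the read-out beyond the scatter, a 7.3-fold higher unbound fraction from compound 1 to compound 4 (0.87 log units; beyond the scatter) and an 11-fold higher unbound fraction from compound 2 to compound 4 (1.04 log units; beyond the scatter). In a physicochemical assay for solubility, with a stated time of 24 h (on this read-out lower numbers stand for lower solubility and higher numbers for higher solubility), compound 3 gives 230 ug/mL. In the physicochemical assay, compound 4 gives > 7440 ug/mL, which is a limit of the assay.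

Open, on these data alone, is how the pyridazin-3-yl group without its methyl would compare with compound 4. Also open, as far as these compounds go, is where a methoxy or an amine in place of methyl or chloro would fall.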